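The source may hold more compounds than are shown below. What is called first, only, known or untested is meant among the compounds shown, and "the series" means these compounds.

Compound 1 `Cn1cc(C2=C(c3nn(CCCn4cncn4)c4ncccc34)C(=O)NC2=O)c2ccccc21` is a starting point with no measured potency to build on. In a functional assay on SMMC-7721 cells (Homo sapiens) for antiproliferative activity, read by MTT assay, with a stated time of 48 h (on this read-out lower numbers stand for stronger inhibition and higher numbers for weaker inhibition), compound 1 gives > 100000 nM, which is a limit of the assay and not a number. Compound 2 `Cn1cc(C2=C(c3nn(CCn4ccnc4)c4ncccc34)C(=O)N(c3ccccc3)C2=O)c2ccccc21` gives > 100000 nM, and this too is a limit. Together they form the only evidence so far: the limit of > 100000 nM in this assay, at which 2 of the 2 values shown sit.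

Compound 3 `Cn1cc(C2=C(c3nn(CCCCn4ccnc4)c4ncccc34)C(=O)NC2=O)c2ccccc21` keeps the shared core of compound 1 but changes its chain ((1H-imidazol-1-yl)methyl in place of 1H-1,2,4-triazol-1-yl on a saturated chain carbon, three bonds along the chain from an aromatic nitrogen). In words, 3-(1H-1,2,4-triazol-1-yl)propyl gives way to 4-(1H-imidazol-1-yl)butyl. Going by the values given here, no measured pair shows what such a change does, so only a small shift towards stronger inhibition in this assay is expected, possibly none beyond the scatter. The estimated step is an at least 1.6-fold lower number from compound 1 to compound 3 (0.22 log units; that floor lies within the scatter), and it remains rough since its starting point is a limit. Compound 3 is expected to give about 60000 nM, with an estimated range of 20000 nM to 100000 nM.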

Compound 3, half-maximal inhibitory concentration: 29200 nM
Compound 3: the middle estimate sits 2.1-fold (0.31 log units) above what was measured, and the stated range covers the measured number.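

In this assay, replacing 3-(1H-1,2,4-triazol-1-yl)propyl with 4-(1H-imidazol-1-yl)butyl on the shared core gives an at least 3.4-fold lower number from compound 1 to compound 3 (0.53 log units; beyond the scatter), so a change at this chain can move the read-out beyond the scatter. That step is only a floor, and the true gap may be larger. Compound 3 is the one compound here that gives a number rather than a limit: the limit of > 100000 nM in this assay, at which 2 of the 3 values shown sit.

The change swaps the ring and lengthens the chain in a single step, so the compounds shown cannot say which of the two carries the effect; a 4-(1H-1,2,4-triazol-1-yl)butyl or a 3-(1H-imidazol-1-yl)propyl chain on the same core would separate them. Also open, going by these compounds, is what happens with a still longer chain, or with an amine in place of the imidazole ring.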